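Swapping the cinnamamide aryl group on a quinazoline core

The source may hold more compounds than are shown below. What is called first, only, known or untested is meant among the compounds shown, and "the series" means these compounds.

Compound 1 `COc1cc(/C=C/C(=O)Nc2cc3c(Nc4ccc(F)c(Cl)c4)ncnc3cc2O[C@H]2CCOC2)cc(OC)c1OC` carries a 3,4,5-trimethoxyphenyl cinnamamide on its core. Going by the values given here, in a functional assay on MCF7 cells (Homo sapiens) for cytotoxicity, read by MTT assay, with a stated time of 72 h (a lower number here means a stronger inhibitor, a higher number a weaker inhibitor), compound 1 gives 28400 nM, the only number reported in this set. Compound 2 `COc1cc2ncnc(Nc3ccc(F)c(Cl)c3)c2cc1NC(=O)/C=C/c1ccc(C#N)cc1` is the other measured member of the set; in this assay compound 2 gives "not active" (no number reported). Compound 3 `COc1ccc(/C=C/C(=O)Nc2cc3c(Nc4ccc(F)c(Cl)c4)ncnc3cc2O[C@H]2CCOC2)cc1` differs from compound 1 as follows: 4-methoxyphenyl in place of 3,4,5-trimethoxyphenyl on a double-bonded chain carbon bound to a double-bonded chain carbon. Among the compounds with values here, with no measured step of this kind at hand, the estimated change from compound 1 to compound 3 is a 1.3-fold higher number from compound 1 to compound 3 (0.13 log units; within the scatter), a small weakening that may still lie within scatter. Compound 3 is expected to give 38000 nM in this assay, in a range of 10000 nM to 140000 nM.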

Compound 3, half-maximal inhibitory concentration: 5070 nM
Beside the measured number, compound 3's estimate is 7.5-fold (0.87 log units) above it, outside the stated range (below it).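

In this assay the swap of 3,4,5-trimethoxyphenyl for 4-methoxyphenyl gives a 5.6-fold lower number from compound 1 to compound 3 (0.75 log units; beyond the scatter) and so provides the first measured sign that the aryl group on this double-bonded chain carbon affects the read-out. Going by these compounds alone, compound 2 differs from compound 1 in more than one place, so only this pair isolates the change. No measurement shown here explains the shift.

The compounds shown leave open how a plain phenyl group or a 4-aminophenyl group would read at this place. They also leave open whether the same swap would give a similar step on another core.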